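The source may hold more compounds than are shown below. What is called first, only, known or untested is meant among the compounds shown, and "the series" means these compounds.

In a functional assay on MCF7 cells (Homo sapiens) for cytotoxicity, read by MTT assay, with a stated time of 72 h (a higher number here means a weaker inhibitor, a lower number a stronger inhibitor), compound 1 `Cc1cc(NC(C)C)nc(SCc2nc3ccccc3[nH]2)n1` gives > 100000 nM, which is a limit and not a number. Compound 2 `Cc1cc(N2CCNCC2)nc(SCc2nc3ccccc3[nH]2)n1` gives > 100000 nM, also a limit. Compound 3 `Cc1cc(NNC(N)=S)nc(SCc2nc3ccccc3[nH]2)n1` gives > 100000 nM, again a limit. Among the measured compounds shown here, the whole series so far therefore comes down to one reading: the limit of > 100000 nM in this assay, at which 3 of the 3 values shown sit. Compound 2 has no number of its own to start from.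

Compound 4 `Cc1ccc(Nc2cc(C)nc(SCc3nc4ccccc4[nH]3)n2)cc1` carries (4-methylphenyl)amino in place of piperazin-1-yl on an aromatic carbon.

The measured steps closest to this change replace a group at the same place. They are a step that the two limits leave unreadable from compound 1 to compound 2 and a step that the two limits leave unreadable from compound 2 to compound 3, along with a step that the two limits leave unreadable from compound 1 to compound 3. None of them has a readable size, so they offer no size to carry over. They show only that none of these three groups gave a measured number in this assay.

The expected move, an at least 1.4-fold lower number from compound 2 to compound 4 (0.15 log units; that floor lies within the scatter), is a rough estimate, small and towards a stronger inhibitor, and compound 4 may well stay at the limit. For compound 4 the estimated value is 70000 nM, with an expected range from 15000 nM to 100000 nM.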

Compound 4, half-maximal inhibitory concentration: 56500 nM
Compound 4: middle estimate off by 1.2-fold (0.09 log units), on the high side, within the range that was stated.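

In this assay, compound 4 is the only one of the four compounds shown that gives a number rather than a limit, so (4-methylphenyl)amino is the one group at this aromatic carbon that yields a readable value. From the compounds shown here alone, its steps are an at least 1.7-fold lower number from compound 2 to compound 4 (0.24 log units; that floor lies within the scatter), an at least 1.7-fold lower number from compound 3 to compound 4 (0.24 log units; that floor lies within the scatter) and an at least 1.7-fold lower number from compound 1 to compound 4 (0.24 log units; that floor lies within the scatter), and each is only a floor, so the true size of these gaps stays unknown. The steps among compound 1, compound 2 and compound 3 still cannot be read, and most of the series remains at a single reading: the limit of > 100000 nM in this assay, at which 3 of the 4 values shown sit.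

The compounds shown leave open whether the ring alone or its methyl group matters, which phenylamino without the methyl could separate. Benzylamino or 4-methoxyphenylamino at the same aromatic carbon would also show whether this reading can move any further.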